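The compounds below may be only part of what the source reports. "The series", "measured", "known", "first", "only" and "open" are said of these compounds alone.

Three related compounds have been tested so far in a functional assay on HCT-116 cells (Homo sapiens) for cytotoxicity, read by MTT assay, with a stated time of 72 h (on this read-out higher numbers stand for weaker inhibition and lower numbers for stronger inhibition), and none of them gives an exact number. Compound 1 `N[C@H]1CC[C@H](Nc2c(C(=O)NCc3ccc(F)cc3)nc(N3CCCCS3(=O)=O)c3cccnc23)CC1` reads > 10000 nM in this assay, which is a limit. Compound 2 `Nc1cccc(Nc2c(C(=O)NCc3ccc(F)cc3)nc(Br)c3cccnc23)c1` reads > 10000 nM, also a limit. Compound 3 `O=C(NCc1ccc(F)cc1)c1nc(Br)c2cccnc2c1NCCCNc1c(C(=O)NCc2ccc(F)cc2)nc(Br)c2cccnc12` reads > 20000 nM, again a limit. Compound 2 therefore has no exact value and stands at the limit of > 10000 nM in this assay, at which 2 of the 3 values shown sit.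

Compound 4 `O=C(NCc1ccc(F)cc1)c1nc(Br)c2cccnc2c1NCc1ccc(F)cc1` has not yet been measured. It differs from compound 2 by 4-fluorobenzyl in place of 3-aminophenyl on a nitrogen on an aromatic ring, with 4-fluorobenzyl in place of 3-aminophenyl on a nitrogen on an aromatic ring.

Among the compounds with values here, no measured pair shows what a change at this place does, so the expectation rests on the reading for compound 2 of > 10000 nM, a limit. No shift beyond the usual scatter is expected, and the estimated change is a number no higher from compound 2 to compound 4 (the limit leaves the size open). For compound 4 the expected half-maximal inhibitory concentration is 10000 nM, with an estimated range of 3000 nM to 30000 nM.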

Compound 4, half-maximal inhibitory concentration: > 20000 nM
Compound 4: a limit, no number; the forecaster's own chance of this, stated with the estimate: 70%; middle value at least 2.0-fold (0.30 log units) away from the limit.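

Compound 2 and compound 4 each give only a limit in this assay, not an exact number, so the step between them cannot be read. The compounds shown leave open how far 4-fluorobenzyl in place of 3-aminophenyl on this nitrogen shifts cytotoxicity.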